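The source may hold more compounds than are shown below. What is called first, only, known or untested is meant among the compounds shown, and "the series" means these compounds.

In a functional assay on PC-9 cells (Homo sapiens) for inhibition, read by MTT assay, with a stated time of 72 h (a higher number here means a weaker inhibitor, a lower number a stronger inhibitor), compound 1 `Cc1cc(Nc2cc(-c3ccccc3)[nH]n2)n2nc(SCc3ccc(F)cc3)nc2n1` gives 8110 nM, the highest of the two numbers on hand. Compound 3 `Cc1cc(Nc2cc(-c3ccccc3)[nH]n2)n2nc(SCc3ccc(Br)cc3)nc2n1` gives 4760 nM in this assay, and a 1.7-fold lower number from compound 1 to compound 3 (0.23 log units; within the scatter) stays within the scatter. Compound 2 `Cc1cc(Nc2cc(-c3ccccc3)[nH]n2)n2nc(SCC3CCCCC3)nc2n1` reaches only a limit of the assay, > 50000 nM, rather than a number (the limit of > 50000 nM in this assay, at which 1 of the 3 values shown sits). Compound 4 `C=CCSc1nc2nc(C)cc(Nc3cc(-c4ccccc4)[nH]n3)n2n1` is not yet measured; it differs from compound 1 by vinyl in place of 4-fluorophenyl on a saturated chain carbon bound to a sulfur. Going by the values given here, the steps that bear on this trade a 4-fluorophenyl or 4-bromophenyl for cyclohexyl at the same place, namely an at least 6.1-fold higher number from compound 1 to compound 2 (0.78 log units; beyond the scatter) and an at least 10-fold lower number from compound 2 to compound 3 (1.02 log units; beyond the scatter), both beyond the scatter. Compound 4 is therefore expected to give 25000 nM, between 9000 nM and 50000 nM, and the estimated step of a 3.1-fold higher number from compound 1 to compound 4 (0.49 log units; beyond the scatter) is expected to weaken inhibition beyond the scatter.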

Compound 4, half-maximal inhibitory concentration: > 50000 nM
Compound 4 gave a limit, no number; the forecaster's own chance of this, stated with the estimate: 35%; at least 2.0-fold (0.30 log units) between middle value and limit.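

In this assay, vinyl in place of 4-fluorophenyl gives an at least 6.1-fold higher number from compound 1 to compound 4 (0.78 log units; beyond the scatter), and vinyl in place of 4-bromophenyl gives an at least 10-fold higher number from compound 3 to compound 4 (1.02 log units; beyond the scatter). Compound 4 stands at a limit of the assay, so a second group without an aromatic ring, here a short unsaturated chain rather than a saturated ring, joins compound 2 in giving no number: the limit of > 50000 nM in this assay, at which 2 of the 4 values shown sit. The step between compound 2 and compound 4 cannot be read, since both values are limits. On these data alone, whether an unsubstituted phenyl or a pyridine ring on this carbon would give a number stays open.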